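The source may hold more compounds than are shown below. What is called first, only, known or untested is meant among the compounds shown, and "the series" means these compounds.

Measured so far:
- compound 1, `CCc1cc(CCc2nc3cccc(F)c3o2)c(O)nc1C`: 8160 nM
- compound 2, `CCc1cc(CCc2nc3c(F)cccc3o2)c(O)nc1C`: 24000 nM

Both compounds were run in a functional assay on a cell-free system (plasma, Homo sapiens) for acid dissociation; a lower number here means tighter binding, a higher number weaker binding. Compound 2 gives the highest number of the two; its nearest neighbour, compound 1, gives a lower number, and that gap lies beyond the usual scatter. Among the measured compounds shown here, no step between two measured compounds that differ in a single place has been worked out, so there is no measured step of this kind to lean on.

The next compound, compound 3, `CCc1cc(CCc2nc3ccccc3o2)c(O)nc1C`, is not yet measured in this assay. It differs from compound 2 as follows: hydrogen in place of fluoro on an aromatic carbon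

For the measured compounds named here, with no measured step for a change of this type, the expectation rests only on the two numbers in hand. The step of a 2.0-fold lower number from compound 2 to compound 3 (0.30 log units; within the scatter) is expected to be a modest decrease in the dissociation constant, not a large one. For compound 3 in this assay the estimated value is 12000 nM, expected to fall between 5000 nM and 30000 nM.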

Compound 3, dissociation constant: 21600 nM
The estimate for compound 3 lay 1.8-fold (0.26 log units) below the measured number; measured number inside the range.
By their numbers in this assay, from the lowest: compound 1; then compounds 3 and 2 (each within the scatter of the next).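

In this assay the swap of fluoro for hydrogen at the place held in compound 2 reads as a 1.1-fold lower number from compound 2 to compound 3 (0.05 log units; within the scatter) and so leaves fluoro and hydrogen indistinguishable there. Among the compounds shown here, the same kind of swap at the place held in compound 1 reads as a 2.6-fold higher number from compound 1 to compound 3 (0.42 log units; beyond the scatter) and is the only one of the two steps beyond the scatter. With compound 3 as the reference without fluoro, the effect of this change therefore depends on where the fluoro sits on the six-membered aromatic ring, and only the placement in compound 1 separates from hydrogen, a reading that rests on these three compounds alone.

Nothing measured here bears on why the two places differ. Going by these compounds, whether a chloro, a methoxy or a methyl group would follow the fluoro of compound 1 at that place, or would stay level with hydrogen as the fluoro of compound 2 does, remains open.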